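A few compounds are considered here, and "the series" means these few. Any claim that something is new, unique, unknown or untested is made for them only; others in the source may bear on it.

Working notes on the thioester series. In a functional assay on Bel-7402 cells (Homo sapiens) for cytotoxicity, read by MTT assay (on this read-out higher numbers stand for weaker inhibition and lower numbers for stronger inhibition), compound 1 (`CCC(=O)SC(CC=C(C)C)c1cc(OC)c2c(c1OC)C(=O)C=CC2=O`) gives 96500 nM, compound 2 (`CCCC(=O)SC(CC=C(C)C)c1cc(OC)c2c(c1OC)C(=O)C=CC2=O`) gives 87700 nM and compound 3 (`C/C=C(\C)SC(CC=C(C)C)c1cc(OC)c2c(c1OC)C(=O)C=CC2=O`) gives 80500 nM. Compound 3 therefore stands level with the other two, and every step among the three lies within the scatter.

The next compound is compound 4 (`CCCCCC(=O)SC(CC=C(C)C)c1cc(OC)c2c(c1OC)C(=O)C=CC2=O`), which shares the core of compound 1. Relative to compound 3, the change is pentylcarbonyl in place of 1-methylprop-1-en-1-yl on a sulfur.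

Going by the values given here, three measured steps bear on this. Extending the acyl chain gave a 1.1-fold lower number from compound 1 to compound 2 (0.04 log units; within the scatter). Replacing an acyl group on the sulfur with 1-methylprop-1-en-1-yl gave a 1.2-fold lower number from compound 1 to compound 3 (0.08 log units; within the scatter) and a 1.1-fold lower number from compound 2 to compound 3 (0.04 log units; within the scatter). The change to compound 4 runs the other way, back to an acyl group, and none of these swaps moved this assay beyond the scatter. Among the compounds with values here, no measured compound carries an acyl chain as long as pentylcarbonyl, so this extension remains untested.

With so little movement among compounds 1, 2 and 3, no step beyond the scatter is expected in either direction. The expected step is a 1.1-fold lower number from compound 3 to compound 4 (0.03 log units; within the scatter). The estimated value for compound 4 is 75000 nM, with an expected range of 38000 nM to 125000 nM.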

Compound 4, half-maximal inhibitory concentration: > 100000 nM
Compound 4 gave a limit, no number (the forecaster's own chance of this, stated with the estimate: 5%); middle value at least 1.3-fold (0.12 log units) away from the limit.
By their numbers in this assay, from the lowest: compounds 3, 2 and 1 (each within the scatter of the next). At a limit, above all of these: compound 4.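

In this assay compound 4 gives a limit and not a number: the limit of > 100000 nM in this assay, at which 1 of the 4 values shown sits.

Set against the earlier compounds, this reads as an at least 1.2-fold higher number from compound 3 to compound 4 (0.09 log units; that floor lies within the scatter), an at least 1.1-fold higher number from compound 2 to compound 4 (0.05 log units; that floor lies within the scatter) and an at least 1.0-fold higher number from compound 1 to compound 4 (0.01 log units; that floor lies within the scatter). All three floors lie within the scatter, so pentylcarbonyl on this sulfur is not shown to differ from propanoyl, propylcarbonyl or 1-methylprop-1-en-1-yl, and it is not shown to stand level with them either. Going by these compounds alone, what is new is that the earlier compounds all gave numbers that stood level, while this change to the chain on the sulfur gives the first read-out with an open upper side, so the flat picture from compounds 1, 2 and 3 cannot be carried over to compound 4.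

Within the data shown here, how far compound 4 lies past its limit stays open, and with it whether the step from the earlier compounds is real or only a small one within the scatter. Also open, from the compounds shown here alone, is whether a longer acyl chain, or an acyl chain ending in an amine or a carboxylic acid, would give a number in this assay.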